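Swapping methoxy for fluoro on a biaryl amide series

A few compounds are considered here, and "the series" means these few. Any claim that something is new, unique, unknown or untested is made for them only; others in the source may bear on it.

Measured so far:
compound 1, `Cc1ccccc1-c1ccc(N(C[C@@H](N)CC(C)C)C(=O)[C@@H]2C[C@H]2c2ccccc2)cc1`, 3400 nM in a functional assay for agonist activity at G protein-coupled receptor 88 (Homo sapiens), read by HTRF and cAMP accumulation; on this read-out lower numbers stand for an effect already at smaller amounts and higher numbers for an effect only at larger amounts of compound
compound 2, `COc1cccc(-c2ccc(N(C[C@@H](N)CC(C)C)C(=O)[C@@H]3C[C@H]3c3ccccc3)cc2)c1`, 1100 nM in this assay

Going by the values given here, compound 2 has the lowest number of the two measured in this assay; its nearest neighbour is compound 1, which gave 3400 nM, and the single measured step, a 3.1-fold lower number from compound 1 to compound 2 (0.49 log units; beyond the scatter), lies beyond the scatter.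

Compound 3, `CC(C)C[C@H](N)CN(C(=O)[C@@H]1C[C@H]1c1ccccc1)c1ccc(-c2cccc(F)c2)cc1`, is not yet measured. It differs from compound 2 in one place: fluoro in place of methoxy on an aromatic carbon. Among the compounds with values here, no measured step here exchanges a methoxy for a fluoro; the only step known, from a 2-methylphenyl to a 3-methoxyphenyl, concerns a different group at a different place, so it gives little guidance. With nothing comparable to lean on, the expected change from compound 2 to compound 3 in this assay is small, a 1.4-fold higher number from compound 2 to compound 3 (0.13 log units; within the scatter), and may not exceed the scatter. Compound 3 is therefore estimated at 1500 nM, with a likely range from 500 nM to 4500 nM.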

Compound 3, half-maximal effective concentration: 2100 nM
Estimate against measurement, compound 3: 1.4-fold (0.15 log units) below; low and high end bracket the measured number.
By their numbers in this assay, from the lowest: compounds 2, 3 and 1 (each within the scatter of the next, the first and the last beyond it).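

In this assay the exchange of methoxy for fluoro, on an aromatic carbon meta to a large group, gives a 1.9-fold higher number from compound 2 to compound 3 (0.28 log units; within the scatter) and so does not separate the two groups, even though fluoro has fewer heavy atoms and no hydrogen-bond acceptor; the oxygen of methoxy is thus not shown to be needed here. The 3-fluorophenyl group also cannot be told apart from 2-methylphenyl, with a 1.6-fold lower number from compound 1 to compound 3 (0.21 log units; within the scatter) on record, whereas 3-methoxyphenyl could be told apart from it. No measurement here explains these readings.

From the compounds shown here alone, whether a hydroxyl, an amine or a carboxylic acid on this same carbon would move the number beyond the scatter remains open. So does whether methoxy and fluoro would also read alike on the other carbons of this ring.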